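A few compounds are considered here, and "the series" means these few. Any claim that something is new, unique, unknown or untested is made for them only; others in the source may bear on it.

Compound 1 `CCCCSc1nc(N)nc2c1ncn2/C=C1/CC1(CO)CO` gives in an ADME assay on MOLT-3 cells (Homo sapiens) for cytotoxicity, with a stated time of 7 days (on this read-out lower numbers stand for higher toxicity in this test and higher numbers for lower toxicity in this test), a value that is a limit, > 20000 nM.
Compound 2 `Nc1nc(NCc2ccccc2)c2ncn(/C=C3/CC3(CO)CO)c2n1` gives in this assay a value that is likewise a limit, > 20000 nM.

Compound 2 thus stands at the limit of > 20000 nM in this assay, at which 2 of the 2 values shown sit. Compound 3 `CCCCCOc1nc(N)nc2c1ncn2/C=C1/CC1(CO)CO` differs from compound 2 by pentyloxy in place of benzylamino on an aromatic carbon. Going by the values given here, the one measured step that bears on this change, a step that the two limits leave unreadable from compound 1 to compound 2, has a size that the two limits leave hidden, so no step beyond the scatter can be read from it. Compound 3 is therefore expected to show a step that the limit leaves unreadable from compound 2 to compound 3. Compound 3 is estimated at 30000 nM, within a range from 15000 nM to 80000 nM.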

Compound 3, half-maximal cytotoxic concentration: > 20000 nM
Compound 3 ended at the assay's limit; the forecaster's own chance of this, stated with the estimate: 85%; the middle value lies beyond the limit too.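

No new step can be read among compound 1, compound 2 and compound 3, because all three stop at a limit: the limit of > 20000 nM in this assay, at which 3 of the 3 values shown sit.

The compounds shown leave open how far each lies past that limit, and whether butylsulfanyl, benzylamino and pentyloxy differ at all in this assay.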